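This account rests on a few compounds, and the source may have more. Where it says the series, first, only, none or still open, it means among the compounds named here.

Three compounds share one core and differ only in the aryl group that sits on a double-bonded chain carbon bound to a double-bonded ring carbon: compound 1 `COc1cccc(/C=C2\CCC/C(=C\c3cccc(Cl)c3)C2=O)c1OC`, compound 2 `COc1cccc(/C=C2\CCC/C(=C\c3ccc(Br)cc3)C2=O)c1OC` and compound 3 `COc1ccc(/C=C2\CCC/C(=C\c3ccccc3Br)C2=O)cc1OC`. In a functional assay on HT-1080 cells (Homo sapiens) for cytotoxicity, read by MTT assay, with a stated time of 72 h (on this read-out lower numbers stand for stronger inhibition and higher numbers for weaker inhibition), compound 1 gives 10300 nM, compound 2 gives 13700 nM and compound 3 gives 8400 nM. Compound 3 has the lowest of the three numbers, yet it lies within the usual scatter of both compound 1 and compound 2, so no ordering among them can be claimed.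

Compound 4 `COc1ccc(/C=C2\CCC/C(=C\c3cc(Cl)cc(Cl)c3)C2=O)cc1OC` is the unmeasured member of the set. It differs from compound 3 in one place: 3,5-dichlorophenyl in place of 2-bromophenyl on a double-bonded chain carbon bound to a double-bonded ring carbon.

For the measured compounds named here, only one measured step speaks to this kind of change. The step of a 1.3-fold higher number from compound 1 to compound 2 (0.12 log units; within the scatter) swapped one halogenated aryl for another at the same place and stayed within the scatter. Nothing in the data separates one halogen pattern from another on this core, so the change from compound 3 to compound 4 is expected to give a step of a 1.1-fold higher number from compound 3 to compound 4 (0.03 log units; within the scatter), which is no real movement in this assay. Compound 4 is therefore estimated at 9000 nM, with a range from 4000 nM to 20000 nM.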

Compound 4, half-maximal inhibitory concentration: 3000 nM
Beside the measured number, compound 4's estimate is 3.0-fold (0.48 log units) above it; the whole stated range lies above it.
By their numbers in this assay, from the lowest: compound 4; then compounds 3, 1 and 2 (each within the scatter of the next).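

In this assay, putting 3,5-dichlorophenyl in place of 2-bromophenyl on a double-bonded chain carbon bound to a double-bonded ring carbon gives a 2.8-fold lower number from compound 3 to compound 4 (0.45 log units; beyond the scatter), a modest change but the first at this place to clear the usual scatter. For the compounds shown here, the earlier swap of one halogenated aryl for another, a 1.3-fold higher number from compound 1 to compound 2 (0.12 log units; within the scatter), stayed within the scatter, so the new step is the first sign that the number can respond to which halogenated aryl sits here. This step alters the kind of halogen and the number of halogen atoms together, so it cannot show which of these matters, and no measurement here explains why the number falls.

On these data alone, it remains open whether 3,5-dichlorophenyl would give a similar step on the core of compound 1, and whether a 3,5-dibromophenyl or a 3-chlorophenyl would behave like it on the core of compound 3. Also open, as far as these compounds go, is what a group without halogen would do at this place, such as plain phenyl or a phenyl carrying an amine or a carboxylic acid.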